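Aryl swap on the carbon double-bonded to nitrogen

A few compounds are considered here, and "the series" means these few. Any claim that something is new, unique, unknown or untested is made for them only; others in the source may bear on it.

Compound 1 `CCCSc1nc(N/N=C/c2ccccc2Cl)c2nnn(Cc3ccccc3)c2n1` gives in a functional assay on ECa-109 cells (Homo sapiens) for antiproliferative activity, read by MTT assay, with a stated time of 72 h (on this read-out lower numbers stand for stronger inhibition and higher numbers for weaker inhibition), 6180 nM. Compound 2 `CCCSc1nc(N/N=C/c2ccc(C)cc2)c2nnn(Cc3ccccc3)c2n1` returns only a limit of the assay in this assay, namely > 64000 nM. Compound 3 `CCCSc1nc(N/N=C/c2cccs2)c2nnn(Cc3ccccc3)c2n1` likewise returns only a limit in this assay, namely > 64000 nM. Compound 3 thus stands at the limit where two of the three values sit (the limit of > 64000 nM in this assay, at which 2 of the 3 values shown sit), and only compound 1 has a number. The step of an at least 10-fold higher number from compound 1 to compound 3 (1.01 log units; beyond the scatter) is large, as is the step of an at least 10-fold higher number from compound 1 to compound 2 (1.01 log units; beyond the scatter), while the step that the two limits leave unreadable from compound 2 to compound 3 cannot be read.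

Compound 4 `CCCSc1nc(N/N=C(\C)c2ccc(Br)cc2)c2nnn(Cc3ccccc3)c2n1` differs from compound 3 by a group of 10 heavy atoms (8 carbon, 1 nitrogen, 1 bromine; one six-membered aromatic ring of carbon only) in place of a group of 7 heavy atoms (5 carbon, 1 nitrogen, 1 sulfur; one five-membered aromatic ring with 1 hetero atom), on a nitrogen on an aromatic ring. The entering group restores a six-membered carbon ring carrying a halogen, which is the side of the step of an at least 10-fold higher number from compound 1 to compound 3 (1.01 log units; beyond the scatter) that gave a number for compound 1, yet compound 2 with > 64000 nM shows that a six-membered carbon ring without a halogen stays at the limit. The expected step of an at least 2.5-fold lower number from compound 3 to compound 4 (0.40 log units; beyond the scatter) is therefore toward a lower number, but with wide uncertainty, and compound 4 may still return a limit. Compound 4 is estimated at 25000 nM, within 6000 nM to 64000 nM.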

Compound 4, half-maximal inhibitory concentration: 4670 nM
Compound 4: the middle estimate sits 5.4-fold (0.73 log units) above what was measured; the whole stated range lies above it.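

In this assay, a measurable result is not confined to the chlorine-containing group of compound 1, as the bromine-containing group of compound 4 also gives a number: an at least 13-fold lower number from compound 3 to compound 4 (1.13 log units; beyond the scatter) and an at least 13-fold lower number from compound 2 to compound 4 (1.13 log units; beyond the scatter). With a 1.3-fold lower number from compound 1 to compound 4 (0.12 log units; within the scatter), the chlorine- and bromine-containing groups cannot be told apart here, and among these compounds both groups containing a halogen give numbers while the two without one do not, with no compound going against this. The step between compound 2 and compound 3 cannot be read, and the two large steps to compound 4 are open-ended, because both start from a limit: the limit of > 64000 nM in this assay, at which 2 of the 4 values shown sit.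

Whether the bromine alone accounts for the number of compound 4 stays open, since its group also differs from that of compound 2 in carbon count. From the compounds shown here alone, whether an amine or a carboxylic acid on the same ring would give a number also stays open.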